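Chloro to methyl on the pendant phenyl: cytotoxicity notes

This account rests on a few compounds, and the source may have more. Where it says the series, first, only, none or still open, it means among the compounds named here.

Compound 1 `Cc1cc(-c2ccc(C(F)(F)F)cc2)cc(C)c1Nc1ccnc(Nc2ccc(C#N)cc2)n1` and compound 2 `Cc1cc(-c2ccccc2Cl)cc(C)c1Nc1ccnc(Nc2ccc(C#N)cc2)n1` share one core and differ only in the pendant aryl. In an ADME assay on MT4 cells (Homo sapiens) for cytotoxicity, read by MTT assay, with a stated time of 4 days (on this read-out higher numbers stand for lower toxicity in this test and lower numbers for higher toxicity in this test), compound 1 gives 4160 nM, and compound 2 gives 3990 nM. The step of a 1.0-fold lower number from compound 1 to compound 2 (0.02 log units; within the scatter) lies within the scatter, so compound 2 stands at one end of the two numbers with compound 1 nearest and effectively level.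

Compound 3 `Cc1ccccc1-c1cc(C)c(Nc2ccnc(Nc3ccc(C#N)cc3)n2)c(C)c1` differs from compound 2 by methyl in place of chloro on an aromatic carbon; cut one bond further out, this reads 2-chlorophenyl to 2-methylphenyl. Going by the values given here, the only measured step bearing on this region, a 1.0-fold lower number from compound 1 to compound 2 (0.02 log units; within the scatter), was flat despite a larger swap on that phenyl, so nothing points to a step beyond the scatter for a chloro to methyl exchange. Compound 3 is therefore expected to stay level, a 1.0-fold higher number from compound 2 to compound 3 (0.00 log units; within the scatter), with an estimated 4000 nM in this assay and a range from 2000 nM to 8000 nM.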

Compound 3, half-maximal cytotoxic concentration: 3820 nM
Compound 3: the middle estimate sits 1.0-fold (0.02 log units) above what was measured; the measured number falls inside the stated range.
By their numbers in this assay, from the lowest: compounds 3, 2 and 1 (each within the scatter of the next).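

Exchanging 2-chlorophenyl for 2-methylphenyl gives a 1.0-fold lower number from compound 2 to compound 3 (0.02 log units; within the scatter) in this assay, so chloro and methyl on this aromatic carbon, ortho to a large group, cannot be told apart on this read-out. The other new comparison, a 1.1-fold lower number from compound 1 to compound 3 (0.04 log units; within the scatter), also stays within the scatter, so 4-(trifluoromethyl)phenyl, 2-chlorophenyl and 2-methylphenyl as the pendant aryl give numbers that cannot be separated in this small set. Nothing available explains why these numbers stay so close.

As far as these compounds go, whether this flat reading would hold with an amine or a carboxylic acid on the pendant phenyl remains open. All three compounds also share the core and its nitrile, so the compounds shown cannot say whether changes elsewhere in the molecule would move the number.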